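Nitrocinnamate esters: methylation of a phenol

This account rests on a few compounds, and the source may have more. Where it says the series, first, only, none or still open, it means among the compounds named here.

Measured so far:
compound 1 `O=C(/C=C/c1ccc(O)c(O)c1[N+](=O)[O-])OCCc1ccccc1` — 8700 nM
compound 2 `O=C(/C=C/c1cc(O)c(O)c([N+](=O)[O-])c1)OCCc1ccccc1` — 11400 nM
compound 3 `COc1c(O)ccc(/C=C/C(=O)OC2CC3CCC2(C)C3(C)C)c1[N+](=O)[O-]` — 21100 nM

All three numbers come from a functional assay on A549 cells (Homo sapiens) for cytotoxicity, read by MTT assay; a lower number here means a stronger inhibitor, a higher number a weaker inhibitor. Compound 2 gives 11400 nM, the second highest of the three; its nearest neighbour is compound 1 and its furthest is compound 3, and both gaps lie within the scatter, so no order can be read among them.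

Compound 4 `COc1cc(/C=C/C(=O)OCCc2ccccc2)cc([N+](=O)[O-])c1O` is not yet measured. It differs from compound 2 by one change: methyl in place of hydrogen on an oxygen on an aromatic ring. For the measured compounds named here, no step of this kind exists among the measured compounds, so its size is open; a step from compound 2 to compound 4 of no more than the usual scatter is expected, with no firm direction. Compound 4 is estimated at 14000 nM, within 6000 nM to 35000 nM, which means an expected step of a 1.2-fold higher number from compound 2 to compound 4 (0.09 log units; within the scatter).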

Compound 4, half-maximal inhibitory concentration: > 300000 nM
Compound 4 ended at the assay's limit (the forecaster's own chance of this, stated with the estimate: 10%); middle value at least 21-fold (1.33 log units) from the limit.
By their numbers in this assay, from the lowest: compounds 1, 2 and 3 (each within the scatter of the next, the first and the last beyond it). At a limit, above all of these: compound 4.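

Methyl in place of hydrogen on an oxygen on an aromatic ring gives the first single-change step in this assay, and it is large: an at least 26-fold higher number from compound 2 to compound 4 (1.42 log units; beyond the scatter). For the compounds shown here, the earlier compounds held no such step, so this is the first sign that activity depends on this hydroxy to methoxy change at this position. Compound 4 stands at a limit of the assay, not at a number: the limit of > 300000 nM in this assay, at which 1 of the 4 values shown sits.

As far as these compounds go, the full size of the step stays open. Also open, from the compounds shown here alone, is whether an ethyl group on this oxygen, or an amine in place of the hydroxy, gives a value within the range of the assay.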